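A few compounds are considered here, and "the series" means these few. Any claim that something is new, unique, unknown or untested is made for them only; others in the source may bear on it.

Of the compounds shown here, three sharing one core have been measured in an assay on Sf9 cells for inhibition of 1-acyl-sn-glycerol-3-phosphate acyltransferase beta (Homo sapiens); on this read-out lower numbers stand for stronger inhibition and higher numbers for weaker inhibition. Compound 1 `CCOc1ccc(Br)cc1-c1cc(Nc2ccc(B(O)O)cc2)nc(N)n1` gives 91 nM in this assay, and compound 2 `Cc1ccc(Cl)cc1-c1cc(Nc2ccc(Br)cc2)nc(N)n1` gives 34 nM. Compound 3 `CCOc1ccc(Cl)cc1-c1cc(Nc2ccccc2Cl)nc(N)n1` gives 4900 nM, the highest of the three numbers; its gap to compound 1 and its still larger gap to compound 2 both lie beyond the usual scatter of repeated measurements, so compound 3 is the weakest inhibitor of the set.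

Compound 4 `CCOc1ccc(Cl)cc1-c1cc(Nc2ccc3c[nH]nc3c2)nc(N)n1` has not yet been measured. It differs from compound 3 in one place: 2H-indazol-6-yl in place of 2-chlorophenyl on a nitrogen on an aromatic ring. For the measured compounds named here, no measured pair shows this exact exchange, so the expectation rests on the spread already seen. Compound 1 at 91 nM and compound 2 at 34 nM show that the group on this nitrogen can move the result far beyond the scatter, and both of those compounds sit far below compound 3.

Compound 4 is therefore expected to land near 200 nM, with a plausible range from 40 nM to 1500 nM. The step from compound 3 to compound 4 is estimated as a 25-fold lower number from compound 3 to compound 4 (1.39 log units; beyond the scatter), a large move toward stronger inhibition and clearly beyond the scatter, though its exact size is uncertain.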

Compound 4, half-maximal inhibitory concentration: 24 nM
Compound 4: middle estimate off by 8.3-fold (0.92 log units), on the high side, and the stated range ends above it.
By their numbers in this assay, from the lowest: compounds 4 and 2 (each within the scatter of the next); then compound 1; then compound 3.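

Read in one place, the exchange of 2-chlorophenyl for 2H-indazol-6-yl on the nitrogen gives a 200-fold lower number from compound 3 to compound 4 (2.31 log units; beyond the scatter) in this assay and turns the weak compound 3 into a strong inhibitor. Each earlier compound differs from compound 3 in more than one place, so the earlier numbers could not tie a change to this nitrogen substituent alone, whereas this pair can. The entering group adds a five-membered aromatic ring with 2 hetero atoms, 1 hydrogen-bond donor and 1 hydrogen-bond acceptor, but no measurement here says which of these features matters or why the number falls so far.

On these data alone, it remains open whether the gain comes from adding the indazole or simply from removing 2-chlorophenyl, a question that a plain phenyl or a naphthyl group on the same nitrogen could help to separate. Also unsettled is whether the same exchange would give a step of similar size on the cores carrying a bromine or a methyl group in compound 1 and compound 2.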